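Chain homologue series on the shared core: compound 1 to compound 3

The source may hold more compounds than are shown below. What is called first, only, known or untested is meant among the compounds shown, and "the series" means these compounds.

Compound 1 `CCCCCC(=O)NCCCN1CCN(CCCNc2ccnc3cc(Cl)ccc23)CC1` carries a hexanamide on the shared core. Among the measured compounds shown here, in an ADME assay on L6 cells (Rattus norvegicus) for cytotoxicity (on this read-out lower numbers stand for stronger inhibition and higher numbers for weaker inhibition), compound 1 gives "not determined" (no result reported), so no number stands for it and no step from it can be sized. For the measured compounds named here, compound 2 `O=C(NCCCN1CCN(CCCNc2ccnc3cc(Cl)ccc23)CC1)c1cccc(OC(F)(F)F)c1` is the only measured member of the series; in this assay compound 2 gives 8500 nM.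

Compound 3 `O=C(CCCc1ccccc1)NCCCN1CCN(CCCNc2ccnc3cc(Cl)ccc23)CC1` differs from compound 1 in one place: phenyl in place of ethyl on a saturated chain carbon, three bonds along the chain from a carbonyl carbon. The amide, the linker and the core are unchanged.

With compound 1 unmeasured, the step from compound 1 to compound 3 in this assay cannot be read from data, and no direction is claimed for it beyond the scatter. Going by the values given here, the only anchor is compound 2, which gives 8500 nM in this assay, and compound 3 shares with it an aromatic ring on the amide side of the shared core.

For compound 3 in this assay the estimate is 15000 nM, expected to fall between 4000 nM and 60000 nM, with a fair chance that only a limit is reported.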

Compound 3, half-maximal inhibitory concentration: 11000 nM
Beside the measured number, compound 3's estimate is 1.4-fold (0.13 log units) above it, within the range that was stated.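

In this assay, the change from 3-(trifluoromethoxy)phenyl to 3-phenylpropyl on the carbonyl carbon gives a 1.3-fold higher number from compound 2 to compound 3 (0.11 log units; within the scatter), so this pair gives the series its first readable step, and the two amides are not told apart on this read-out. For these two compounds alone, replacing a directly attached aromatic ring with a phenyl ring carried on a saturated chain leaves the number within the scatter, and the trifluoromethoxy group can be lost with no change that can be read. No supporting data bear on why the two values lie so close.

Going by these compounds, the step from compound 1 to compound 3, ethyl to phenyl on the saturated chain, cannot be read, so what the phenyl itself contributes remains unknown. Also open, on these data alone, is whether a carboxylic acid or an amine at the end of this chain, or a longer chain carrying the same phenyl, would move the number beyond the scatter.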